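Cytotoxicity notes on a phenoxy-substituted series

The compounds below may be only part of what the source reports. "The series", "measured", "known", "first", "only" and "open" are said of these compounds alone.

Measured so far:
compound 1, `Nc1cc(N)c2nc(-c3ccccc3)c(Oc3ccc(Cl)c(Cl)c3)nc2c1` — < 100000 nM
compound 2, `CCOC(=O)[C@H](CCC(=O)O)NC(=O)c1ccc(Sc2nc3cc(N)cc(N)c3nc2-c2ccccc2)cc1` — < 100000 nM

In a functional assay on ACHN cells (Homo sapiens) for inhibition, read by sulforhodamine B assay, with a stated time of 48 h (a lower number here means that less compound is tolerated, a higher number that more compound is tolerated), compound 1 gives only a limit, < 100000 nM, not a number. Compound 2 likewise gives only a limit in this assay, < 100000 nM. Both values sit at the same bound, as the evidence shows: the limit of < 100000 nM in this assay, at which 2 of the 2 values shown sit. Among the compounds with values here, no step between two measured compounds is available, so compound 1 stands at a limit without a numerical position relative to anything else.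

Compound 3, `Nc1cc(N)c2nc(-c3ccccc3)c(Oc3ccc(F)cc3)nc2c1`, is not yet measured. It differs from compound 1 by 4-fluorophenyl in place of 3,4-dichlorophenyl on an oxygen on an aromatic ring. Within the data shown here, with no measured step to lean on, the expectation is that the change from compound 1 to compound 3 carries no step beyond the scatter; the expected step is a step that the limit leaves unreadable from compound 1 to compound 3. Compound 3 is therefore estimated to give 50000 nM in this assay, in a range from 10000 nM to 100000 nM, with a real chance that only a limit is reported.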

Compound 3, concentration lethal to 50% of the cells: 81300 nM
For compound 3 the middle estimate is 1.6-fold (0.21 log units) below the measured one; low and high end bracket the measured number.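

In this assay, within the data shown here, compound 1 gives < 100000 nM as a limit and not a number, so no step to compound 3 can be read, because the comparison rests on that bound: the limit of < 100000 nM in this assay, at which 2 of the 3 values shown sit.

The compounds shown leave open how 4-fluorophenyl and 3,4-dichlorophenyl compare on that oxygen in this assay.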